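Ethoxymethyl for propoxycarbonyl: an expected step in cytotoxicity

The compounds below may be only part of what the source reports. "The series", "measured", "known", "first", "only" and "open" are said of these compounds alone.

Compound 1 `CCCOC(=O)c1c(C)coc1-c1ccc2c(CC)cccc2c1OC` was tested in a functional assay on MDA-MB-231 cells (Homo sapiens) for cytotoxicity, read by MTT assay, with a stated time of 72 h; a lower number here means that less compound is needed, a higher number that more compound is needed for the effect. In this assay compound 1 gives > 10 ug/mL, which is a limit of the assay and not a number, so compound 1 stands only at that limit. Compound 2 `CCc1cccc2c(OC)c(-c3occ(C)c3C(=O)On3nnc4ccccc43)ccc12` carries a group of 9 heavy atoms in place of a group of 3 heavy atoms on an oxygen next to a carbonyl group. In this assay compound 2 gives > 10 ug/mL, again a limit. The step that the two limits leave unreadable from compound 1 to compound 2 therefore cannot be read. Compound 3 `CCc1cccc2c(OC(C)=O)c(-c3occ(C)c3COC(C)=O)ccc12` in this assay gives > 10 ug/mL, also a limit. All that is known is the limit of > 10 ug/mL in this assay, at which 3 of the 3 values shown sit.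

Compound 4 `CCOCc1c(C)coc1-c1ccc2c(CC)cccc2c1OC` differs from compound 1 by ethoxymethyl in place of propoxycarbonyl on an aromatic carbon. Among the measured compounds shown here, no measured step bears on this change; the only measured step concerns another site and has no readable size. With compound 1 at the limit, the step from compound 1 to compound 4 is expected to be a step that the limit leaves unreadable from compound 1 to compound 4, most likely not beyond the scatter. Compound 4 is therefore estimated at 15 ug/mL, within the range 7 ug/mL to 40 ug/mL in this assay, with a fair chance that only a limit is reported.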

Compound 4, concentration for half-maximal effect: 9.1 ug/mL
Compound 4: the middle estimate sits 1.6-fold (0.22 log units) above what was measured, and the stated range covers the measured number.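

In this assay compound 4 is the only compound shown that gives a number and not a limit: the limit of > 10 ug/mL in this assay, at which 3 of the 4 values shown sit. Ethoxymethyl in place of propoxycarbonyl on this aromatic carbon gives an at least 1.0-fold lower number from compound 1 to compound 4 (0.04 log units; that floor lies within the scatter) and that figure is only a floor, so the true size of the step stays unknown. The position thus carries a group without the carbonyl of propoxycarbonyl and still gives a readable value, though the floor alone does not show that the change has any effect.

As far as these compounds go, whether a longer ether chain, an amine or a carboxylic acid on this aromatic carbon would move the number remains open. From the compounds shown here alone, how far compound 1 really lies from compound 4 also remains open, as compound 1 has only a limit.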